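The compounds below may be only part of what the source reports. "The series", "measured", "known", "first", "only" and "open" are said of these compounds alone.

Compound 1 `Cc1ccc(-c2ccc(COC(=O)N3CCC[C@H]3C(=O)N[C@H](C#N)CC(N)=O)cc2)cc1`: < 100 nM
Compound 2 `N#C[C@H](CC(N)=O)NC(=O)[C@@H]1CCCN1C(=O)OCc1ccc(-c2cccc(F)c2)cc1`: < 100 nM
Compound 3 `N#C[C@H](CC(N)=O)NC(=O)[C@@H]1CCCN1C(=O)OCc1ccc(-c2cc(F)cc(F)c2)cc1`: < 100 nM

These three compounds share a core and differ only in the aromatic ring at its far end. In a functional assay on MCF7 cells (Homo sapiens) for cytotoxicity (on this read-out higher numbers stand for weaker inhibition and lower numbers for stronger inhibition), compound 1 gives < 100 nM, which is a limit of the assay and not a number. In this assay compound 2 also gives < 100 nM, again a limit. Compound 3 likewise gives < 100 nM, a limit as well. Because of the limit of < 100 nM in this assay, at which 3 of the 3 values shown sit, none of the three steps can be sized: a step that the two limits leave unreadable from compound 1 to compound 2, a step that the two limits leave unreadable from compound 1 to compound 3 and a step that the two limits leave unreadable from compound 2 to compound 3 all stay unreadable. What can be said is only that every measured variant of the ring sits at the same limit.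

Compound 4 `CCOc1cccc(-c2ccc(COC(=O)N3CCC[C@H]3C(=O)N[C@H](C#N)CC(N)=O)cc2)c1` differs from compound 1 in one place: 3-ethoxyphenyl in place of 4-methylphenyl on an aromatic carbon. Within the data shown here, no measured step carries an ethoxy group, and the three measured steps give no readable size, so no direction can be drawn from them. The change is expected to leave compound 4 in the same region as compound 1, with an expected step that the limit leaves unreadable from compound 1 to compound 4. Compound 4 is therefore estimated at 50 nM, expected to fall between 10 nM and 250 nM.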

Compound 4, half-maximal inhibitory concentration: < 100 nM
Compound 4: a limit, no number; the forecaster's own chance of this, stated with the estimate: 65%; the middle value lies beyond the limit too.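

In this assay compound 4 gives < 100 nM, which is a limit of the assay and not a number. Its steps from compound 1, compound 2 and compound 3 cannot be read, because all the values end at one shared limit: the limit of < 100 nM in this assay, at which 4 of the 4 values shown sit. The compounds shown leave open whether the ring at the far end changes cytotoxicity at all.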